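The source may report more compounds than this note shows. Statements on the series, on what has been measured and on what is new or still open speak of the compounds shown alone.

Compound 1 `O=C(/C=C\Nc1ccc(C(F)(F)F)cc1)c1cn(-c2ccccc2)nc1-c1ccc(Cl)cc1` was tested in a functional assay on A549 cells (Homo sapiens) for antiproliferative activity, read by MTT assay, with a stated time of 48 h; on this read-out lower numbers stand for stronger inhibition and higher numbers for weaker inhibition. Compound 1 gives > 50000 nM, which is a limit of the assay and not a number. Compound 2 `O=C(/C=C\Nc1ccc(O)cc1)c1cn(-c2ccccc2)nc1-c1ccc(Cl)cc1` gives 1910 nM. Compound 3 `COc1cc(-c2nn(-c3ccccc3)cc2C(=O)/C=C\Nc2ccc(C(F)(F)F)cc2)cc(OC)c1OC` gives > 50000 nM, again only a limit of the assay.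

Compound 2 differs from compound 1 by hydroxy in place of trifluoromethyl on an aromatic carbon. That change made an at least 26-fold lower number from compound 1 to compound 2 (1.41 log units; beyond the scatter), a step that starts from the limit of > 50000 nM in this assay, at which 2 of the 3 values shown sit, and so is known only as a lower bound. Compound 3 differs from compound 1 in the core, by 3,4,5-trimethoxyphenyl in place of 4-chlorophenyl on an aromatic carbon, and the size of that step is a step that the two limits leave unreadable from compound 1 to compound 3.

Compound 4 `COc1cc(-c2nn(-c3ccccc3)cc2C(=O)/C=C\Nc2ccc(O)cc2)cc(OC)c1OC` is not yet measured in this assay. It differs from compound 3 by hydroxy in place of trifluoromethyl on an aromatic carbon, the same change that turned compound 1 into compound 2, at the same place. The account expects the step of an at least 12-fold lower number from compound 3 to compound 4 (1.09 log units; beyond the scatter) beside the earlier at least 26-fold lower number from compound 1 to compound 2 (1.41 log units; beyond the scatter), resting on the value of compound 2, 1910 nM, as the only numbered point. For compound 4 the estimate is 4000 nM, from 600 nM to 30000 nM, with a real chance that only a limit is again reported.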

Compound 4, half-maximal inhibitory concentration: 3160 nM
Compound 4: middle estimate off by 1.3-fold (0.10 log units), on the high side, within the range that was stated.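

In this assay, hydroxy in place of trifluoromethyl on an aromatic carbon gave an at least 15-fold lower number from compound 3 to compound 4 (1.19 log units; beyond the scatter), so the number fell on the core of compound 3 as it had on the core of compound 1. Set side by side, the two steps read: the same change on two cores in this assay, an at least 26-fold lower number (1.41 log units; beyond the scatter) from compound 1 to compound 2 and an at least 15-fold lower number (1.19 log units; beyond the scatter) from compound 3 to compound 4; the limit leaves it open whether they differ. Both steps start from a limit of the assay, so each is only a lower bound, and the two pairs show the direction of the change on these two cores but not its true size or whether that size depends on the core: the limit of > 50000 nM in this assay, at which 2 of the 4 values shown sit.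

The compounds shown leave open what other groups at this place would do, such as an amine or a carboxylic acid, and so whether the gain depends on hydroxy itself or only on the loss of trifluoromethyl. They also leave open whether the change would carry over to a core with another group, such as a methyl, in place of 4-chlorophenyl or 3,4,5-trimethoxyphenyl.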